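Adding a second chloro to a chlorinated purine-like core

A few compounds are considered here, and "the series" means these few. Any claim that something is new, unique, unknown or untested is made for them only; others in the source may bear on it.

Measured compounds:
- compound 1 `ClCc1ccc(Cn2cnc3c(Cl)ncnc32)cc1`, 21900 nM
- compound 2 `Nc1nc(Cl)c2ncn(Cc3ccccc3CCl)c2n1`, 27500 nM
- compound 3 `ClCc1ccccc1Cn1cnc2nc(Cl)nc(Cl)c21`, "not determined" (no result reported)

In a functional assay on SNB-19 cells (Homo sapiens) for cytotoxicity, read by sulforhodamine B assay, with a stated time of 48 h (a lower number here means a stronger inhibitor of growth, a higher number a weaker inhibitor of growth), compound 1 gives 21900 nM. Compound 2 gives 27500 nM in this assay, and the gap between the two numbers lies within the usual scatter, so the two cannot be told apart. Within the data shown here, compound 3 gives "not determined" (no result reported) in this assay, so only two numbers are known, and there is no pair of measured compounds differing in one place from which a step could be read.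

Compound 4 `ClCc1ccc(Cn2cnc3c(Cl)nc(Cl)nc32)cc1` is not yet measured. It differs from compound 1 by chloro in place of hydrogen on an aromatic carbon. Among the measured compounds shown here, nothing among the measured compounds shows what such a change does here, so the expectation rests on compound 1 alone, with the step from compound 1 to compound 4 expected to stay within the scatter. The estimate for compound 4 is 20000 nM, in a range from 8000 nM to 60000 nM, which means an expected step of a 1.1-fold lower number from compound 1 to compound 4 (0.04 log units; within the scatter).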

Compound 4, concentration for total growth inhibition: 7080 nM
Estimate against measurement, compound 4: 2.8-fold (0.45 log units) above; the whole stated range lies above it.
By their numbers in this assay, from the lowest: compound 4; then compounds 1 and 2 (each within the scatter of the next).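

In this assay, among these compounds, chloro in place of hydrogen on an aromatic carbon, between two ring nitrogen atoms, gives a 3.1-fold lower number from compound 1 to compound 4 (0.49 log units; beyond the scatter) and is the first step in this set that can be read. This position is therefore not silent: a change of a single heavy atom here moves the number by a modest amount, beyond the scatter. No measurement shown here bears on the reason for this step.

Chloro is the only group compared with hydrogen at this position, so it remains open whether a fluoro, methyl or methoxy group there would move the number in the same direction or by a similar amount. Going by these compounds, it also remains open whether the chloro step would carry over to compounds that differ from compound 1 elsewhere in the structure.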